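A few compounds are considered here, and "the series" means these few. Any claim that something is new, unique, unknown or untested is made for them only; others in the source may bear on it.

Measured so far in an ADME assay on liver (Rattus norvegicus) for activation, read by HPLC; on this read-out lower numbers stand for a shorter-lived compound and higher numbers for a longer-lived compound:
- compound 1 `CCCCCCOC(=O)NCCCC(C)Nc1cc(OC)cc2cccnc12` gives 10.4 h
- compound 2 `COc1ccc(OC(=O)NCCCC(C)Nc2cc(OC)cc3cccnc23)cc1` gives 10.3 h
- compound 3 `COc1cc(NC(C)CCCNC(=O)OCC(F)(F)F)c2ncccc2c1` gives 13.7 h

Compound 3 at 13.7 h lies within the scatter of both other compounds, so the three values form a single level. The next compound is compound 4 `COc1cc(NC(C)CCCNC(=O)Oc2ccccc2)c2ncccc2c1`, and the change is phenyl in place of 2,2,2-trifluoroethyl on an oxygen next to a carbonyl group with phenyl in place of 2,2,2-trifluoroethyl on an oxygen next to a carbonyl group.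

For the measured compounds named here, three measured steps bear on this. The closest is a 1.3-fold higher number from compound 2 to compound 3 (0.12 log units; within the scatter) and it joins the same 2,2,2-trifluoroethyl group to a 4-methoxyphenyl group. The other two are a 1.3-fold higher number from compound 1 to compound 3 (0.12 log units; within the scatter) and a 1.0-fold lower number from compound 1 to compound 2 (0.00 log units; within the scatter) and neither leaves the scatter. Going by the values given here, no measured compound carries phenyl itself, so the nearest guide is compound 2 at 10.3 h for now.

No change beyond the scatter is expected in this assay, and the expected step is a 1.3-fold lower number from compound 3 to compound 4 (0.12 log units; within the scatter) in this estimate. For compound 4 the estimated value is 10.5 h, with an expected range of 6.5 h to 16 h in this assay.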

Compound 4, half-life in the liver assay: 9.5 h
The estimate for compound 4 lay 1.1-fold (0.04 log units) above the measured number, within the range that was stated.
By their numbers in the liver assay, from the lowest: compounds 4, 2, 1 and 3 (each within the scatter of the next).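

In the liver assay, phenyl on an oxygen next to a carbonyl group does not separate from the groups already seen there: a 1.4-fold lower number from compound 3 to compound 4 (0.16 log units; within the scatter), a 1.1-fold lower number from compound 1 to compound 4 (0.04 log units; within the scatter). Hydrogen in place of methoxy on an aromatic carbon of the phenyl group also leaves the read-out on the same level, with a 1.1-fold lower number from compound 2 to compound 4 (0.04 log units; within the scatter), so hexyl, 4-methoxyphenyl, 2,2,2-trifluoroethyl and phenyl all sit together at this position. This single level holds even though the change from 2,2,2-trifluoroethyl to phenyl separates the two compounds clearly in a physicochemical assay for lipophilicity, read by HPLC, in phosphate buffer, measured as octanol-water partition, with a stated time of 30 min, at pH 7.4 (a lower number here means a more polar compound, a higher number a more lipophilic compound), where compound 3 gives 3.41 and compound 4 gives 4.27: the measured distribution coefficient of compound 3, 3.41, and of compound 4, 4.27, a number 0.86 log units higher (beyond the scatter)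

On these data alone, whether an amine or a carboxylic acid on the phenyl group, or a chain longer than hexyl, would leave this level remains open. Also open, as far as these compounds go, is whether the level would hold on a different core, since all four compounds share one.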